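Lengthening the chain: compound 2 to compound 3

This account rests on a few compounds, and the source may have more. Where it says the series, first, only, none or still open, it means among the compounds named here.

Measured so far in a functional assay on P388 cells (Mus musculus) for cytotoxicity; on this read-out higher numbers stand for weaker inhibition and lower numbers for stronger inhibition:
- compound 1 `C#C[C@H](O)/C=C/CCCCC/C=C\CCCC/C=C\CCCCCCCCC/C=C/[C@@H](O)C#C`: 160 nM
- compound 2 `C#C[C@H](O)/C=C/CCCCCCC/C=C\CCCC/C=C\CCCCCCCCC/C=C/[C@@H](O)C#C`: 160 nM

Compound 2 gives 160 nM and stands level with compound 1, its nearest neighbour on these numbers. The next structure is compound 3 `C#C[C@H](O)/C=C/CCCCCCCCC/C=C\CCCC/C=C\CCCCCCCCC/C=C/[C@@H](O)C#C`, and the change from compound 2 is a group of 8 heavy atoms (7 carbon, 1 oxygen; no ring) in place of a group of 6 heavy atoms (5 carbon, 1 oxygen; no ring), on a saturated chain carbon, seven bonds along the chain from a double-bonded chain carbon. This is a group of 8 heavy atoms in place of a group of 6 heavy atoms, on a saturated chain carbon, seven bonds along the chain from a double-bonded chain carbon.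

Among the compounds with values here, only one measured step bears on this: no change at the digits printed from compound 1 to compound 2 (within the scatter). It has the same swap of groups, but five bonds along the chain from a double-bonded chain carbon. A single step is thin evidence, and the data do not show whether the pattern holds at the new place. On the strength of that step, no change beyond the scatter is expected in this assay, and no direction is favoured. The expected size of the step is no change at the digits printed from compound 2 to compound 3 (within the scatter). Compound 3 is estimated at 160 nM, with an expected range from 70 nM to 370 nM.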

Compound 3, half-maximal inhibitory concentration: 160 nM
Compound 3: middle estimate and measured number agree at the digits printed, and the stated range covers the measured number.
By their numbers in this assay, from the lowest: compounds 1, 2 and 3 (each within the scatter of the next).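

In this assay, the group of 8 heavy atoms in place of the group of 6 heavy atoms, on a saturated chain carbon, seven bonds along the chain from a double-bonded chain carbon, gives no change at the digits printed from compound 2 to compound 3 (within the scatter), so the flat result of the earlier step now also holds at this second place. Read end to end, the two steps give no change at the digits printed from compound 1 to compound 3 (within the scatter), which shows that the larger overall swap also stays within the scatter and that no small shift builds up across the two steps. No measurement at hand offers an explanation for this flat read-out.

These three compounds show only hydrocarbon extension of this one chain segment in this single cell assay, so a still longer chain, or a shorter one than in compound 1, could behave differently. As far as these compounds go, whether an amine or a carboxylic acid on this chain would move the number also stays open, as does any change to the terminal alkyne and hydroxyl groups that all three compounds share.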